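The source may hold more compounds than are shown below. What is called first, only, known or untested is meant among the compounds shown, and "the series" means these compounds.

Working notes on the series.

Compound 1 `COC(=O)[C@@]1(C)CC[C@@H]2C3=C1CC[C@@H](C)[C@]3(C)C[C@@H]1c3ccccc3N[C@H]21` is the reference point: in a functional assay on HBL-100 cells (Homo sapiens) for inhibition, read by sulforhodamine B assay, with a stated time of 48 h (a higher number here means a weaker inhibitor of growth, a lower number a stronger inhibitor of growth), compound 1 gives 78000 nM. Compound 3 `COC(=O)[C@@]1(C)CC[C@@H]2C3=C1CC[C@@H](C)[C@]3(C)C[C@@H]1c3cccc(C)c3N[C@H]21` carries one change against compound 1, (methyl in place of hydrogen on an aromatic carbon), and in this assay compound 3 gives 32000 nM. The step is a 2.4-fold lower number from compound 1 to compound 3 (0.39 log units; beyond the scatter).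

Compound 2 `COC(=O)[C@@]1(C)CC[C@@H]2C3=C1CC[C@@H](C)[C@]3(C)Cc1c2[nH]c2ccccc12` has a different core; how the core of compound 2 differs from the core of compound 1 is not broken down here. In this assay compound 2 gives 3500 nM, which stands apart from the two others, with both compound 3 and compound 1 giving higher numbers by margins beyond the scatter.

Compound 4 `COC(=O)[C@@]1(C)CC[C@@H]2C3=C1CC[C@@H](C)[C@]3(C)Cc1c2[nH]c2c(C)cccc12` is compound 2 with the change (methyl in place of hydrogen on an aromatic carbon), and it has not yet been measured. The surroundings of the place are described in the same words as for the change from compound 1 to compound 3, so this is the same change made on the core of compound 2 rather than on the core of compound 1.

For compound 4 the expectation in this assay is a step of a 1.9-fold lower number from compound 2 to compound 4 (0.29 log units; within the scatter), resting on the earlier step of a 2.4-fold lower number from compound 1 to compound 3 (0.39 log units; beyond the scatter); whether that step carries over from one core to the other is not known from what is shown, so the range is kept wide. Compound 4 is thus estimated at 1800 nM, expected between 600 nM and 5000 nM.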

Compound 4, concentration for 50% growth inhibition: 13000 nM
Beside the measured number, compound 4's estimate is 7.2-fold (0.86 log units) below it; measured number outside the range, above it.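

On the core of compound 2, methyl in place of hydrogen on an aromatic carbon gives a 3.7-fold higher number from compound 2 to compound 4 (0.57 log units; beyond the scatter) in this assay, so this core loses ground with the added methyl where the core of compound 1 gained it. The change therefore does not carry over unaltered between these two cores, and the two steps differ in direction as well as in number: the same change on two cores in this assay, a 2.4-fold lower number (0.39 log units; beyond the scatter) from compound 1 to compound 3 and a 3.7-fold higher number (0.57 log units; beyond the scatter) from compound 2 to compound 4, 9.1-fold (0.96 log units) apart, beyond the scatter of two such steps. This rests on a single matched pair on each core, with one group at one place and in one assay, so it shows that the effect of the methyl depends on the core in this pair of cores but gives neither a general rule for the series nor a reason for the reversal.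

The compounds shown leave open whether the opposite steps are particular to methyl or would also appear with another group at the same place, such as fluorine, methoxy or an amine, made on both cores. They also leave open whether a methyl elsewhere on the six-membered aromatic ring would split the two cores in the same way, and whether the split would hold in other cell lines.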